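The source may report more compounds than this note shows. Statements on the series, on what has been measured and on what is new or still open speak of the compounds shown alone.

Measured in a functional assay on HepG2 cells (Homo sapiens), read by MTT assay, with a stated time of 48 h; on this read-out higher numbers stand for weaker inhibition and lower numbers for stronger inhibition:
- compound 1 `CCN(CC)CCNC(=O)c1ccc(C(CC)(CC)c2ccc(OCC(O)C(C)(C)C)c(C)c2)n1CC`: 490 nM
- compound 2 `C#CCNC(=O)c1ccc(C(CC)(CC)c2ccc(OCC(O)C(C)(C)C)c(C)c2)n1CC`: > 50000 nM, a limit of the assay and not a number

Compound 2 stands at the limit of > 50000 nM in this assay, at which 1 of the 2 values shown sits. Compound 3 `CCn1c(C(=O)NCC(OC)OC)ccc1C(CC)(CC)c1ccc(OCC(O)C(C)(C)C)c(C)c1` differs from it in one place: dimethoxymethyl in place of ethynyl on a saturated chain carbon bound to an amide-type nitrogen. In words, dimethoxymethyl stands in place of ethynyl on a saturated chain carbon bound to an amide-type nitrogen, turning propargylcarbamoyl into (2,2-dimethoxyethyl)carbamoyl.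

Among the measured compounds shown here, one measured step bears on this change, and it is large: an at least 100-fold higher number from compound 1 to compound 2 (2.00 log units; beyond the scatter), with ethynyl in place of (diethylamino)methyl at the same place. No measured step starts from the limit itself, so the size of the new change is not shown directly. For the measured compounds named here, compound 3 carries no (diethylamino)methyl either, so with compound 1 at 490 nM as the only measured number, no clear return towards compound 1 is expected in this assay. The expected change is none beyond the scatter, estimated as an at least 1.2-fold lower number from compound 2 to compound 3 (0.09 log units; that floor lies within the scatter). For compound 3 the estimated value is 40000 nM, with an expected range from 10000 nM to 80000 nM.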

Compound 3, half-maximal inhibitory concentration: 23200 nM
Estimate against measurement, compound 3: 1.7-fold (0.24 log units) above; measured number inside the range.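

In this assay, on the saturated chain carbon bound to an amide-type nitrogen, dimethoxymethyl gives a measured number without the (diethylamino)methyl group, with an at least 2.1-fold lower number from compound 2 to compound 3 (0.33 log units; beyond the scatter). That step is only a floor, and its true size stays unknown, because compound 2 stands at a limit of the assay and not at a number: the limit of > 50000 nM in this assay, at which 1 of the 3 values shown sits. Even so, the replacement of (diethylamino)methyl by dimethoxymethyl remains costly, with a 47-fold higher number from compound 1 to compound 3 (1.68 log units; beyond the scatter), so among the three compounds shown, neither replacement for (diethylamino)methyl comes close to the number of the compound that carries it.

The compounds shown do not tell whether the amine nitrogen of (diethylamino)methyl or the size of that group accounts for this gap, and a dimethylamino or pyrrolidine group on the same carbon, set against a plain branched alkyl chain of similar size, would separate the two. They also leave open whether the oxygen atoms of dimethoxymethyl matter for the step from ethynyl, which a comparison with an isopropyl group or a single methoxymethyl group at this place could address.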